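The source may hold more compounds than are shown below. What is called first, only, known or untested is meant among the compounds shown, and "the series" means these compounds.

Measured in an ADME assay on HepG2 2.2.15 cells (Homo sapiens) for cytotoxicity, read by MTT assay; a lower number here means that less compound is tolerated, a higher number that more compound is tolerated:

- Compound 1 `C=C1CC[C@@H]2[C@](C)(COC(=O)c3ccccc3)[C@H](O)CC[C@@]2(C)[C@@H]1C/C=C1\C=COC1=O`: 82000 nM
- Compound 2 `C=C1CC[C@@H]2[C@](C)(COC(=O)CCCC)[C@H](O)CC[C@@]2(C)[C@@H]1C/C=C1\C=COC1=O`: 225000 nM

Going by the values given here, compound 2 stands at the top of these numbers with 225000 nM, and compound 1 is its only neighbour. Compound 3 `C=C1CC[C@@H]2[C@](C)(COC(=O)c3ccccc3C(=O)O)[C@H](O)CC[C@@]2(C)[C@@H]1C/C=C1\C=COC1=O`, not yet measured, has 2-carboxyphenyl in place of butyl on a carbonyl carbon.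

Among the compounds with values here, one measured step bears on this change: a 2.7-fold higher number from compound 1 to compound 2 (0.44 log units; beyond the scatter). Within the data shown here, it is modest, and it is the only comparison of an aromatic ring with butyl at this place. Compound 3 again carries a six-membered aromatic ring, as compound 1 does, so a move back toward a lower number in this assay is expected, no larger than the measured step. Among the measured compounds shown here, the data hold no compound with the added carboxyl substituent on that ring, so this expectation is loose and the range is wide. The expected change is a 1.7-fold lower number from compound 2 to compound 3 (0.24 log units; within the scatter). For compound 3 the estimated value is 130000 nM, with an expected range from 55000 nM to 330000 nM.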

Compound 3, half-maximal cytotoxic concentration: 450000 nM
For compound 3 the middle estimate is 3.5-fold (0.54 log units) below the measured one; measured number outside the range, above it.
By their numbers in this assay, from the lowest: compound 1; then compounds 2 and 3 (each within the scatter of the next).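

In this assay, replacing butyl with 2-carboxyphenyl on this carbonyl carbon gives a 2.0-fold higher number from compound 2 to compound 3 (0.30 log units; within the scatter), so compound 3 and compound 2 cannot be told apart here, even though one carries an aromatic ring and the other has no ring. The earlier comparison had set an unsubstituted phenyl against butyl, and it now appears that an aromatic ring at this place does not by itself go with the lower number: adding carboxy to the ring of compound 1 gives a 5.5-fold higher number from compound 1 to compound 3 (0.74 log units; beyond the scatter), a step beyond the scatter and the largest difference among these three compounds. Among these compounds, then, only compound 1, with its unsubstituted phenyl, stands apart, although nothing in the data explains this result.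

On these data alone, whether the carboxylic acid itself matters, or any added group on that ring would do the same, remains open, and a methyl ester or an amine on the ring would help to separate these possibilities. As far as these compounds go, it is equally open whether a carboxylic acid at the end of a butyl chain, or a longer chain in place of butyl, would behave like compound 2 or move the number further.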